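Moving a Methyl Group on a Short-Lived Compound

A few compounds are considered here, and "the series" means these few. Any claim that something is new, unique, unknown or untested is made for them only; others in the source may bear on it.

Compound 1 `Cc1ccccc1CNC(=O)n1c(N)nc2ccccc21` was tested in an ADME assay on a cell-free system (plasma, Mus musculus) for metabolic stability, read by HPLC, with a stated time of 120 min, tested at 2 uM; on this read-out higher numbers stand for a longer-lived compound and lower numbers for a shorter-lived compound. In this assay compound 1 gives only a limit, < 0.0834 h, and so stands at the lowest point of the measured values (the limit of < 0.0834 h in this assay, at which 1 of the 3 values shown sits). Compound 3 `Cc1ccccc1CNC(=O)n1cnc2ccccc21` gives 0.733 h. Compound 2 `COc1nc2ccccc2n1C(=O)NCCCCc1ccccc1` sits at the other limit of this assay, > 2 h (the limit of > 2 h in this assay, at which 1 of the 3 values shown sits). Among the compounds with values here, the only measured step, an at least 8.7-fold higher number from compound 1 to compound 3 (0.94 log units; beyond the scatter), concerns a different change. Compound 4 `Cc1cccc(CNC(=O)n2c(N)nc3ccccc32)c1` differs from compound 1 by 3-methylphenyl in place of 2-methylphenyl on a saturated chain carbon bound to an amide-type nitrogen. Within the data shown here, no measured step covers this change, so no step beyond the scatter is expected, and a limit may again be reported. Compound 4 is expected at 0.06 h, between 0.02 h and 0.2 h, an expected step that the limit leaves unreadable from compound 1 to compound 4.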

Compound 4, half-life: < 0.0834 h
Compound 4 ended at the assay's limit; the forecaster's own chance of this, stated with the estimate: 65%; the middle value lies beyond the limit too.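

Compound 1 and compound 4 both sit at the same limit, so no step can be read between them: the limit of < 0.0834 h in this assay, at which 2 of the 4 values shown sit.

As far as these compounds go, how long either compound really lasts in this assay, and whether 3-methylphenyl or 2-methylphenyl gives the longer-lived compound, remains open.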